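The source may hold more compounds than are shown below. What is called first, only, known or untested is meant among the compounds shown, and "the series" means these compounds.

Three compounds with a shared core, differing only in the aromatic group on one aromatic carbon, have been measured in a functional assay on MDA-MB-231 cells (Homo sapiens) for antiproliferative activity, read by MTT assay, with a stated time of 48 h; on this read-out higher numbers stand for weaker inhibition and lower numbers for stronger inhibition. In that assay compound 1 (`C=CS(=O)(=O)N1CCN(c2ncnc3sc(-c4ccc(C(F)(F)F)cc4)cc23)CC1`) gives 6410 nM, compound 2 (`C=CS(=O)(=O)N1CCN(c2ncnc3sc(-c4cccc5ncccc45)cc23)CC1`) gives 21000 nM and compound 3 (`C=CS(=O)(=O)N1CCN(c2ncnc3sc(-c4ccc(OC)nc4)cc23)CC1`) gives 9270 nM. The exchanges of group show a 1.4-fold higher number from compound 1 to compound 3 (0.16 log units; within the scatter), so those two cannot be told apart. By contrast, the data show a 3.3-fold higher number from compound 1 to compound 2 (0.52 log units; beyond the scatter) and a 2.3-fold lower number from compound 2 to compound 3 (0.36 log units; beyond the scatter), which leaves compound 3 alongside compound 1 and apart from compound 2.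

Compound 4 (`C=CS(=O)(=O)N1CCN(c2ncnc3sc(-c4ccc(F)nc4)cc23)CC1`) carries a 6-fluoropyridin-3-yl group where compound 3 has 6-methoxypyridin-3-yl. This puts fluoro in place of methoxy on an aromatic carbon, next to the ring nitrogen and para to a large group: fluoro in place of methoxy on an aromatic carbon. Among the compounds with values here, no measured step changes this substituent alone, so the evidence is indirect. The nearest guide is the exchange of the whole group, which gave a 1.4-fold higher number from compound 1 to compound 3 (0.16 log units; within the scatter), while the largest exchange seen gave a 3.3-fold higher number from compound 1 to compound 2 (0.52 log units; beyond the scatter) and involved the quinolin-5-yl group, which is absent here. A shift beyond the scatter is therefore not expected in this assay, and no direction can be favoured. The estimated change is a 1.0-fold lower number from compound 3 to compound 4 (0.01 log units; within the scatter). For compound 4 the expected value is 9000 nM, with an estimated range from 4500 nM to 18000 nM.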

Compound 4, half-maximal inhibitory concentration: 16000 nM
Beside the measured number, compound 4's estimate is 1.8-fold (0.25 log units) below it, and the stated range covers the measured number.
By their numbers in this assay, from the lowest: compounds 1, 3, 4 and 2 (each within the scatter of the next, the first and the last beyond it).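

Read directly for the first time in this assay, the change of methoxy to fluoro, next to the ring nitrogen and para to a large group, gives a 1.7-fold higher number from compound 3 to compound 4 (0.24 log units; within the scatter) and so does not separate the two compounds. Compound 4 nevertheless stands differently from compound 3 against the other two groups: the data give a 1.3-fold lower number from compound 2 to compound 4 (0.12 log units; within the scatter) and also a 2.5-fold higher number from compound 1 to compound 4 (0.40 log units; beyond the scatter), which places the 6-fluoropyridin-3-yl group alongside quinolin-5-yl and apart from 4-(trifluoromethyl)phenyl, whereas 6-methoxypyridin-3-yl could not be told apart from 4-(trifluoromethyl)phenyl and was distinct from quinolin-5-yl. No accompanying measurement bears on why this small exchange leaves the two pyridine compounds on different sides of these comparisons.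

The compounds shown leave open how an amine or a longer alkoxy chain in this same place would read in this assay, so the span of this position rests on two substituents only. They also leave open whether the exchange of methoxy for fluoro would read the same on a phenyl ring, as in 4-fluorophenyl against 4-methoxyphenyl on the shared core.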